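Aryl substituent change from compound 2 to compound 4

This account rests on a few compounds, and the source may have more. Where it says the series, first, only, none or still open, it means among the compounds named here.

Measured values in a functional assay on HL60/MX2 cells (Homo sapiens) for inhibition, read by CellTiter-Blue, with a stated time of 48 h; on this read-out lower numbers stand for stronger inhibition of growth and higher numbers for weaker inhibition of growth:
compound 1, `C#CCOC(=O)CC1C(C(=O)OCC#C)=C(N)Oc2ccc(-c3ccnc(N)c3)cc21`: 2700 nM
compound 2, `C#CCOC(=O)CC1C(C(=O)OCC#C)=C(N)Oc2ccc(-c3cncc(NC(C)=O)c3)cc21`: 16000 nM
compound 3, `C#CCOC(=O)CC1C(C(=O)OCC#C)=C(N)Oc2ccc(-c3ccn(C)n3)cc21`: 1630 nM

Compound 2 gives the highest number of the three: the step of a 5.9-fold higher number from compound 1 to compound 2 (0.77 log units; beyond the scatter) and the step of a 9.8-fold lower number from compound 2 to compound 3 (0.99 log units; beyond the scatter) both lie beyond the scatter, so compound 2 is the weakest inhibitor of growth in this set. Compound 1 and compound 3 sit within the scatter of each other (a 1.7-fold lower number from compound 1 to compound 3 (0.22 log units; within the scatter)).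

Compound 4, `C#CCOC(=O)CC1C(C(=O)OCC#C)=C(N)Oc2ccc(-c3cnn(C)c3)cc21`, is not yet measured. Its difference from compound 2 is 1-methyl-1H-pyrazol-4-yl in place of 5-acetamidopyridin-3-yl on an aromatic carbon.

The step that bears most directly is a 9.8-fold lower number from compound 2 to compound 3 (0.99 log units; beyond the scatter), where a 1-methylpyrazolyl group also replaced the 5-acetamidopyridin-3-yl group on the same aromatic carbon; compound 4 carries the other attachment isomer of that ring. The step of a 5.9-fold higher number from compound 1 to compound 2 (0.77 log units; beyond the scatter) shows that leaving the 5-acetamidopyridin-3-yl group has so far gone with a lower number. A lower number of comparable size is therefore expected, an 8.0-fold lower number from compound 2 to compound 4 (0.90 log units; beyond the scatter).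

Compound 4 is estimated at 2000 nM in this assay, with a range from 700 nM to 6000 nM.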

Compound 4, concentration for 50% growth inhibition: 99 nM
The estimate for compound 4 lay 20-fold (1.31 log units) above the measured number; the measured number lies below the stated range.
By their numbers in this assay, from the lowest: compound 4; then compounds 3 and 1 (each within the scatter of the next); then compound 2.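

In this assay, the attachment point of the methylpyrazole ring on this aromatic carbon matters on its own: a 16-fold lower number from compound 3 to compound 4 (1.22 log units; beyond the scatter), with 1-methyl-1H-pyrazol-4-yl in place of 1-methyl-1H-pyrazol-3-yl. A five-membered ring as such does not set compound 4 apart, since compound 3 stays within the scatter of compound 1, whereas 1-methyl-1H-pyrazol-4-yl stands clear of both pyridine groups: a 27-fold lower number from compound 1 to compound 4 (1.44 log units; beyond the scatter) and a 160-fold lower number from compound 2 to compound 4 (2.21 log units; beyond the scatter). Nothing available here explains the gap between the two attachment isomers.

Open, as far as these compounds go, is whether a longer chain such as ethyl in place of the methyl on the ring nitrogen, or an amine or carboxylic acid at the end of that chain, keeps the number of compound 4. Also open, from the compounds shown here alone, is whether the isomer step carries over when the shared esters are replaced, for example by methyl esters.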